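The source may report more compounds than this note shows. Statements on the series, on what has been measured and on what is new or still open speak of the compounds shown alone.

Measured compounds in this series:

Compound 1, `Oc1ccc(-c2ccc(-c3ccc(-c4nc5ccccc5[nH]4)cc3)cc2)cc1`: 46300 nM
Compound 2, `COc1ccc(-c2ccc(-c3ccc(-c4nc5ccccc5[nH]4)cc3)cc2)cc1`: 100000 nM
Compound 3, `Oc1ccc(-c2ccc(-c3ccc(-c4nc5c(O)cccc5[nH]4)cc3)cc2)cc1`: 2700 nM

In a functional assay on DWD cells (Homo sapiens) for inhibition, read by sulforhodamine B assay (on this read-out lower numbers stand for stronger inhibition of growth and higher numbers for weaker inhibition of growth), compound 1 gives 46300 nM and compound 2 gives 100000 nM. The two are linked by one change, (methyl in place of hydrogen on an oxygen on an aromatic ring), and this step is a 2.2-fold higher number from compound 1 to compound 2 (0.33 log units; beyond the scatter). Compound 3 carries the core of compound 1 with one addition, (hydroxy in place of hydrogen on an aromatic carbon); the step is a 17-fold lower number from compound 1 to compound 3 (1.23 log units; beyond the scatter), and compound 3 has the lowest of the three numbers.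

Compound 4, `COc1ccc(-c2ccc(-c3ccc(-c4nc5c(O)cccc5[nH]4)cc3)cc2)cc1`, is not yet measured in this assay. It stands to compound 3 as compound 2 stands to compound 1: the change is methyl in place of hydrogen on an oxygen on an aromatic ring, the same change as before, with the same place in both cases. The expectation is that this step reproduces the earlier one, giving a 2.2-fold higher number from compound 3 to compound 4 (0.35 log units; beyond the scatter), resting on the step of a 2.2-fold higher number from compound 1 to compound 2 (0.33 log units; beyond the scatter). Among the compounds with values here, compound 4 is therefore expected to give 6000 nM, with a likely range from 2500 nM to 16000 nM; the range is wide because only one such step, a 2.2-fold higher number from compound 1 to compound 2 (0.33 log units; beyond the scatter), is available as guide.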

Compound 4, concentration for 50% growth inhibition: 6400 nM
For compound 4 the middle estimate is 1.1-fold (0.03 log units) below the measured one, within the range that was stated.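

In this assay, hydroxy to methoxy on the aromatic ring gives a 2.4-fold higher number from compound 3 to compound 4 (0.37 log units; beyond the scatter) and matches the same change on the other core: the same change on two cores in this assay, a 2.2-fold higher number (0.33 log units; beyond the scatter) from compound 1 to compound 2 and a 2.4-fold higher number (0.37 log units; beyond the scatter) from compound 3 to compound 4, 1.1-fold (0.04 log units) apart, within the scatter of two such steps.
The added hydroxy on an aromatic carbon gives a 16-fold lower number from compound 2 to compound 4 (1.19 log units; beyond the scatter) and also holds whether the far end of the molecule carries hydroxy or methoxy: the same change on two cores in this assay, a 17-fold lower number (1.23 log units; beyond the scatter) from compound 1 to compound 3 and a 16-fold lower number (1.19 log units; beyond the scatter) from compound 2 to compound 4, 1.1-fold (0.04 log units) apart, within the scatter of two such steps.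
Across these four compounds, the two changes therefore carry from one core to the other without any visible dependence on each other, but this rests on a single pair of steps for each change and does not show that either would hold on a core outside this set or in a different test.

The compounds shown leave open whether a longer chain such as ethoxy on the same oxygen would continue the methyl step. They also leave open whether an amine or a carboxylic acid in place of the added hydroxy would reproduce its large step.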